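The source may hold more compounds than are shown below. What is called first, only, known or untested is meant among the compounds shown, and "the series" means these compounds.

Measured so far in an ADME assay on L6 cells (Rattus norvegicus) for cytotoxicity, read by resazurin assay, with a stated time of 72 h; on this read-out lower numbers stand for stronger inhibition and higher numbers for weaker inhibition:
- compound 1 `O=[N+]([O-])c1cn2c(n1)OC[C@H](OCc1ccc(-c3ccc(C(F)(F)F)cc3Cl)cn1)C2`: 50000 nM
- compound 2 `O=[N+]([O-])c1cn2c(n1)OC[C@@H](OCc1cccc(-c3cccc(OC(F)(F)F)c3)c1)C2`: 13000 nM

Compound 1 has the higher number of the two, and the gap to compound 2 lies beyond the usual scatter, so compound 1 is the weaker inhibitor here. Compound 3 `O=[N+]([O-])c1cn2c(n1)OC[C@@H](OCc1ccc(-c3ccc(C(F)(F)F)cc3Cl)cn1)C2` is built from the same atoms and bonds as compound 1: the two compounds have the same atoms and bonds and differ only in configuration as drawn: 1 of 1 stereo elements differ; a stereocentre at a saturated ring carbon is drawn R in compound 1 and S in compound 3. A stereocentre at a saturated ring carbon is drawn R in compound 1 and S in compound 3. Within the data shown here, no measured pair shows what this swap does in this assay, so only a small move towards lower numbers is expected. The expected change is a 1.4-fold lower number from compound 1 to compound 3 (0.15 log units; within the scatter). Compound 3 is estimated at 35000 nM, within a range of 12000 nM to 90000 nM.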

Compound 3, half-maximal inhibitory concentration: 57000 nM
Beside the measured number, compound 3's estimate is 1.6-fold (0.21 log units) below it, and the stated range covers the measured number.
By their numbers in this assay, from the lowest: compound 2; then compounds 1 and 3 (each within the scatter of the next).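

Swapping the stereocentre at a saturated ring carbon from R to S gives a 1.1-fold higher number from compound 1 to compound 3 (0.06 log units; within the scatter) in this assay, so for this pair the drawn configuration at this position makes no difference that can be told from scatter. The earlier compounds shown here could not show this, as they differ in more than one place. Here the swap can be read on its own: the fact that compounds 1 and 3 differ only in the configuration as drawn

From the compounds shown here alone, it remains open whether the same swap would matter as little on compound 2, whose side chain differs. Also open, going by these compounds, is what an amine or a carboxylic acid in place of the trifluoromethyl group of compound 1 would do in this assay.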